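The compounds below may be only part of what the source reports. "The series", "measured", "known", "first", "only" and "open" are said of these compounds alone.

Of the compounds shown here, three that share one core have been measured in an assay on CHO-K1 cells for antagonist activity at adenosine receptor A1 (Homo sapiens), read by a beta-galactosidase reporter, with stated times of 15 min and 6 h; on this read-out higher numbers stand for weaker inhibition and lower numbers for stronger inhibition. Compound 1 `Nc1nc(-c2ccco2)nc2sc(CN3CCC(O)CC3)cc12` gives 4000 nM. Compound 2 `CCc1ccc(-c2nc(N)c3cc(CN4[C@H](C)CCC[C@@H]4C)sc3n2)o1` gives 190 nM. Compound 3 `CC(C)c1ccc(-c2nc(N)c3cc(CN4[C@H](C)CCC[C@@H]4C)sc3n2)o1` gives 140 nM, the lowest of the three numbers; its gap to compound 2 is within the usual scatter, while its gap to compound 1 is beyond it. Compound 4 `C[C@@H]1CCC[C@H](C)N1Cc1cc2c(N)nc(-c3ccc(C4CC4)o3)nc2s1` has not been measured; it differs from compound 3 by cyclopropyl in place of isopropyl on an aromatic carbon. Going by the values given here, the only step that touches the same part of the molecule, a 1.4-fold lower number from compound 2 to compound 3 (0.13 log units; within the scatter), stayed within the scatter, so a change of similar small size, with no clear direction, is expected for a 1.1-fold higher number from compound 3 to compound 4 (0.06 log units; within the scatter). Compound 4 is therefore expected to give about 160 nM, most likely between 60 nM and 420 nM.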

Compound 4, inhibition constant: 330 nM
The estimate for compound 4 lay 2.1-fold (0.31 log units) below the measured number; measured number inside the range.
By their numbers in this assay, from the lowest: compounds 3, 2 and 4 (each within the scatter of the next, the first and the last beyond it); then compound 1.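

In this assay, going by these compounds alone, replacing 5-isopropylfuran-2-yl with 5-cyclopropylfuran-2-yl gives a 2.4-fold higher number from compound 3 to compound 4 (0.37 log units; beyond the scatter) and is the first step at this position to pass beyond the scatter, although both groups hold 3 heavy atoms and differ by the three-membered ring. Measured against ethyl, the same cyclopropyl gives a 1.7-fold higher number from compound 2 to compound 4 (0.24 log units; within the scatter) and stays within the scatter, so this position has so far shown only a modest response. Nothing available explains this shift. Open, as far as these compounds go, is how an amine, a carboxylic acid or a longer chain would fare at this position.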